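This account rests on a few compounds, and the source may have more. Where it says the series, first, only, none or still open, it means among the compounds named here.

Measured so far:
compound 1 `CN(Cc1ccc(Oc2ccccc2)cc1)Cc1cn(C)c2ccc(CNc3ccc(F)cc3)cc12`, 9980 nM
compound 2 `CN(Cc1ccc(-c2ccccc2)cc1)Cc1cn(C)c2ccc(CNc3ccc(F)cc3)cc12`, 8180 nM
compound 3 `CN1CCN(Cc2cn(C)c3ccc(C(=O)Nc4ccc(F)cc4)cc23)CC1`, 24800 nM

In a functional assay on HeLa cells (Homo sapiens) for antiproliferative activity, read by MTT assay, with a stated time of 72 h (a higher number here means a weaker inhibitor, a lower number a stronger inhibitor), compound 2 gives the lowest of the three numbers, but compound 1 stands within the scatter of it; only compound 3 lies clearly higher. Within the data shown here, the single one-change step, a 1.2-fold lower number from compound 1 to compound 2 (0.09 log units; within the scatter), concerns phenyl in place of phenoxy and says nothing about the amide end. Compound 4 `CN(Cc1ccc(-c2ccccc2)cc1)Cc1cn(C)c2ccc(C(=O)Nc3ccc(F)cc3)cc12` differs from compound 2 by (4-fluorophenyl)carbamoyl in place of ((4-fluorophenyl)amino)methyl on an aromatic carbon. Among the measured compounds shown here, no measured step covers this change alone; compound 3 carries the same carbamoyl but also a different amine, so its higher number cannot be assigned to the amide change by itself. The expected step is a 1.5-fold higher number from compound 2 to compound 4 (0.17 log units; within the scatter), small and, if anything, toward a higher number. The estimate for compound 4 in this assay is 12000 nM, with a range of 5000 nM to 30000 nM.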

Compound 4, half-maximal inhibitory concentration: 23600 nM
The estimate for compound 4 lay 2.0-fold (0.29 log units) below the measured number; the measured number falls inside the stated range.
By their numbers in this assay, from the lowest: compounds 2 and 1 (each within the scatter of the next); then compounds 4 and 3 (each within the scatter of the next).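

In this assay, among these compounds, a 2.9-fold higher number from compound 2 to compound 4 (0.46 log units; beyond the scatter) is the first single change here that lies beyond the scatter, so this position responds to the change from ((4-fluorophenyl)amino)methyl to (4-fluorophenyl)carbamoyl. With the carbamoyl in place, compound 4 at 23600 nM and compound 3 at 24800 nM stand within the scatter of each other, so the change of amine shows no separation between them. Nothing available explains the step. Open, on these data alone, is how a sulfonamide or a longer chain at this position would compare, and whether phenoxy in place of phenyl stays silent alongside the carbamoyl.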